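Three Level Compounds and a Fourth Awaiting Measurement

The source may hold more compounds than are shown below. What is called first, only, known or untested is meant among the compounds shown, and "the series" means these compounds.

In a functional assay on SK-MEL-28 cells (Homo sapiens) for inhibition, read by MTT assay, with a stated time of 72 h (on this read-out higher numbers stand for weaker inhibition of growth and lower numbers for stronger inhibition of growth), compound 1 (`CC(C)(C)OC(=O)/C=C/C1=CC[C@H]2C(C)(C)CCC[C@]2(C)[C@H]1C=O`) gives 41000 nM, compound 2 (`CC1(C)CCC[C@]2(C)[C@@H](C=O)C(/C=C/C(=O)OCc3ccccc3)=CC[C@@H]12`) gives 39000 nM and compound 3 (`CC1(C)CCC[C@]2(C)[C@@H](C=O)C(/C=C/C#N)=CC[C@@H]12`) gives 42000 nM. Compound 3 therefore stands level with the other two, within the scatter of both, and the numbers do not separate the three. Compound 4 (`C#CCCCOC(=O)/C=C/C1=CC[C@H]2C(C)(C)CCC[C@]2(C)[C@H]1C=O`) differs from compound 3 at one place: ((pent-4-yn-1-yl)oxy)carbonyl in place of cyano on a double-bonded chain carbon bound to a double-bonded chain carbon. In words, this puts ((pent-4-yn-1-yl)oxy)carbonyl in place of cyano on a double-bonded chain carbon bound to a double-bonded chain carbon. Within the data shown here, two measured steps bear on this change. The first, a 1.0-fold higher number from compound 1 to compound 3 (0.01 log units; within the scatter), exchanges tert-butoxycarbonyl for cyano at that same place and stays within the scatter. The second, a 1.1-fold lower number from compound 1 to compound 2 (0.02 log units; within the scatter), exchanges tert-butyl for benzyl on the oxygen of that group and also stays within the scatter. Neither step tests the pentynyl chain itself, and three compounds are a thin basis, but neither gives a reason to expect movement. The expected result is no change beyond the scatter, and the estimated size is a 1.1-fold lower number from compound 3 to compound 4 (0.04 log units; within the scatter). For compound 4 the estimated value in this assay is 38000 nM, with an expected range from 19000 nM to 70000 nM.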

Compound 4, concentration for 50% growth inhibition: 36000 nM
Estimate against measurement, compound 4: 1.1-fold (0.02 log units) above; measured number inside the range.
By their numbers in this assay, from the lowest: compounds 4, 2, 1 and 3 (each within the scatter of the next).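

In this assay, among these compounds, the step of a 1.2-fold lower number from compound 3 to compound 4 (0.07 log units; within the scatter) is the first test of the pent-4-yn-1-yl chain: ((pent-4-yn-1-yl)oxy)carbonyl, with 8 heavy atoms, enters on a double-bonded chain carbon bound to a double-bonded chain carbon, where cyano, with 2, leaves, and the two numbers are not separated. The chain also stays level with the two other esters, as pent-4-yn-1-yl in place of tert-butyl gives a 1.1-fold lower number from compound 1 to compound 4 (0.06 log units; within the scatter) and but-3-yn-1-yl in place of phenyl gives a 1.1-fold lower number from compound 2 to compound 4 (0.03 log units; within the scatter) in this comparison, so among these four compounds none goes against a flat picture at this place. Why the numbers stay level cannot be said, as nothing measured here bears on the reason.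

Going by these compounds, whether a carboxylic acid or an amide at this place, or an amine at the end of the chain, would separate from these four remains open. So does whether a longer chain on the oxygen would do so, and the aldehyde on the shared core, common to all four, is left untested by these comparisons.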